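Swapping the aryl arm of a quinazoline-type core

The source may report more compounds than this note shows. Statements on the series, on what has been measured and on what is new or still open speak of the compounds shown alone.

Compound 1 `FC(F)(F)c1ccccc1-c1nc(NCc2ccc(-c3cncnc3)cc2)c2ccccc2n1`: 3000 nM
Compound 2 `O=[N+]([O-])c1ccccc1-c1nc(NCc2ccc(-c3cccnc3)cc2)c2ccccc2n1`: 7800 nM

In an assay on a protein complex for inhibition of ubiquitin carboxyl-terminal hydrolase 1/WD repeat-containing protein 48 (Homo sapiens), read by fluorescence (a higher number here means a weaker inhibitor, a lower number a stronger inhibitor), compound 2 gives the highest number of the two, and its gap to compound 1 lies beyond the usual scatter. Compound 3 `c1cncc(-c2ccc(CNc3nc(-n4ccnc4)nc4ccccc34)cc2)c1` differs from compound 2 in one place: 1H-imidazol-1-yl in place of 2-nitrophenyl on an aromatic carbon. A larger aryl group is thus exchanged for a smaller five-membered ring on an aromatic carbon of the shared core. Within the data shown here, no measured pair shows this change, so the direction is open; a modest move toward a weaker inhibitor is expected, a 1.4-fold higher number from compound 2 to compound 3 (0.15 log units; within the scatter). For compound 3 an estimate of 11000 nM is made, with a range from 3000 nM to 40000 nM.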

Compound 3, half-maximal inhibitory concentration: "not active" (no number reported)
No number was reported for compound 3; no gap can be computed for the estimate.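

Among these compounds, compound 3 is reported only as "not active", without a number, so no step from compound 2 to compound 3 can be read. Nothing shown here offers an explanation for this result. The compounds shown leave open how large the effect of replacing 2-nitrophenyl with 1H-imidazol-1-yl is.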